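Amine tail variation on the shared core in A549 proliferation

The source may report more compounds than this note shows. Statements on the series, on what has been measured and on what is new or still open speak of the compounds shown alone.

Measured compounds:
compound 1 `CCN(CC)CCCOc1cc2ncnc(Nc3ccc(C#N)cc3)c2cc1OC`: 50600 nM
compound 2 `COc1cc2c(Nc3ccc(C#N)cc3)ncnc2cc1OCCCN1CCC(O)CC1`: 29900 nM

In a functional assay on A549 cells (Homo sapiens) for antiproliferative activity, read by MTT assay, with a stated time of 72 h (a lower number here means a stronger inhibitor, a higher number a weaker inhibitor), compound 1 stands at the highest of the two numbers, with compound 2 nearest at a 1.7-fold lower number from compound 1 to compound 2 (0.23 log units; within the scatter). Compound 3 `COc1cc2c(Nc3ccc(C#N)cc3)ncnc2cc1OCCCN1CCC(N2CCCCC2)CC1` is not yet measured. From compound 1 it differs by 4-(piperidin-1-yl)piperidin-1-yl in place of diethylamino on a saturated chain carbon, three bonds along the chain from an oxygen on an aromatic ring. Among the compounds with values here, the only measured step bearing on this change is a 1.7-fold lower number from compound 1 to compound 2 (0.23 log units; within the scatter), and it does not leave the scatter; no step tests the second ring entering here. On that basis no step beyond the scatter is expected in this assay, and for compound 3 the estimated value is 30000 nM (range 10000 nM to 90000 nM), meaning an expected step of a 1.7-fold lower number from compound 1 to compound 3 (0.23 log units; within the scatter).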

Compound 3, half-maximal inhibitory concentration: 30700 nM
For compound 3 the middle estimate is 1.0-fold (0.01 log units) below the measured one; measured number inside the range.
By their numbers in this assay, from the lowest: compounds 2, 3 and 1 (each within the scatter of the next).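

In this assay, the second ring is now tested at this position: 4-(piperidin-1-yl)piperidin-1-yl in place of diethylamino gives (a 1.6-fold lower number from compound 1 to compound 3 (0.22 log units; within the scatter)) and piperidin-1-yl in place of hydroxy on a saturated ring carbon gives (a 1.0-fold higher number from compound 2 to compound 3 (0.01 log units; within the scatter)). Going from 5 to 12 heavy atoms on the saturated chain carbon thus leaves all three compounds within the scatter of one another. No evidence on hand bears on this result.

Going by these compounds, whether a morpholine or a piperazine at the chain end would step beyond the scatter remains open. On these data alone, the effect of a shorter or longer chain also remains open.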